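Swapping one aryl ring for another on a hydroxamic acid

The source may report more compounds than this note shows. Statements on the series, on what has been measured and on what is new or still open speak of the compounds shown alone.

Compound 1 `O=C(CCCCCCc1nc2ccc(Cl)cc2[nH]1)NO` and compound 2 `O=C(CCCCCCc1nc2ccc(-c3cccc(F)c3)cc2[nH]1)NO` share a core carrying a hydroxamic acid on a chain, and differ only in the group attached to an aromatic carbon of that core. In a functional assay on SK-OV-3 cells (Homo sapiens) for cytotoxicity (a higher number here means a weaker inhibitor, a lower number a stronger inhibitor), compound 1 gives 320 nM, while compound 2 gives 1500 nM. Within the data shown here, the single step measured so far, a 4.7-fold higher number from compound 1 to compound 2 (0.67 log units; beyond the scatter), shows that replacing chloro with 3-fluorophenyl weakened activity. Among the measured compounds shown here, on the numbers in hand, compound 2 stands as the higher of the two, with compound 1 as its only neighbour.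

Compound 3 `CN(C)c1ccc(-c2ccc3nc(CCCCCCC(=O)NO)[nH]c3c2)cc1` is not yet measured. 4-(dimethylamino)phenyl in place of 3-fluorophenyl on an aromatic carbon Here one aryl ring replaces another, so the measured step, which compares an aryl ring with a chloro, bears on this change only loosely; nothing in the data compares two aryl rings with each other. Without such a comparison, the expectation is a step of no change at the digits printed from compound 2 to compound 3 (within the scatter), that is, no change beyond the scatter. Compound 3 is therefore estimated at 1500 nM, with a range from 500 nM to 4500 nM.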

Compound 3, half-maximal inhibitory concentration: 6600 nM
Compound 3: middle estimate off by 4.4-fold (0.64 log units), on the low side; the measured number lies above the stated range.
By their numbers in this assay, from the lowest: compound 1; then compound 2; then compound 3.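

In this assay, the choice of aryl ring on this aromatic carbon clearly matters: replacing 3-fluorophenyl with 4-(dimethylamino)phenyl gives a 4.4-fold higher number from compound 2 to compound 3 (0.64 log units; beyond the scatter) even though both groups hold one six-membered aromatic ring of carbon only, so having a ring here does not by itself set the number. Replacing chloro with 4-(dimethylamino)phenyl gives a 21-fold higher number from compound 1 to compound 3 (1.31 log units; beyond the scatter) and is a larger loss than the earlier swap to 3-fluorophenyl, which makes compound 1 the strongest inhibitor of the three and compound 3 the weakest. No measurement offered here explains why the second aryl ring does worse than the first.

The two aryl rings differ both in what they carry and in where they carry it, as their names show, so these compounds cannot tell which of those two differences matters. From the compounds shown here alone, it also remains open how an unsubstituted phenyl ring or a methoxyphenyl ring would compare with these two rings on the same carbon, and whether a small group such as fluoro or methyl would match chloro in this assay or fall away from it.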